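The source may report more compounds than this note shows. Statements on the series, on what has been measured and on what is new or still open speak of the compounds shown alone.

Within the data shown here, the three compounds measured so far share one core and differ at two points. Compound 1 `O=C(N/N=C/c1ccccc1O)c1cc(-c2ccc(Cl)cc2)nn1Cc1ccc(Cl)nc1` gives 22500 nM in a functional assay on A549 cells (Homo sapiens) for cytotoxicity, read by MTT assay, with a stated time of 48 h; on this read-out higher numbers stand for higher solubility and lower numbers for lower solubility. Compound 2 `COc1ccc(-c2cc(C(=O)N/N=C/c3ccccc3O)n(Cc3ccc(Cl)nc3)n2)cc1` gives 70000 nM in this assay, and compound 3 `CC(C)(C)c1ccc(Cn2nc(-c3ccc(Cl)cc3)cc2C(=O)N/N=C/c2ccccc2O)cc1` gives 36000 nM. Compound 3 sits between the other two on these numbers, yet its gaps to compound 1 and to compound 2 are both within the scatter, so no real difference from either can be claimed.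

The step to compound 4 `COc1ccc(-c2cc(C(=O)N/N=C/c3ccccc3O)n(Cc3ccc(C(C)(C)C)cc3)n2)cc1` is methoxy in place of chloro on an aromatic carbon. The same change has been seen once before, on a different partner group, where a 3.1-fold higher number from compound 1 to compound 2 (0.49 log units; beyond the scatter). The other known step, a 1.6-fold higher number from compound 1 to compound 3 (0.20 log units; within the scatter), alters a separate part of the molecule and only fixes the starting point for compound 4. Among the measured compounds shown here, whether the same change repeats in the same size on the new partner is unknown, since only one example exists.

A rise of similar size is expected for compound 4 because a 3.1-fold higher number from compound 1 to compound 2 (0.49 log units; beyond the scatter) was a modest but clear rise, giving an expected step of a 2.8-fold higher number from compound 3 to compound 4 (0.44 log units; beyond the scatter). For compound 4 the estimated value in this assay is 100000 nM, with a range from 45000 nM to 220000 nM.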

Compound 4, solubility: 22000 nM
Compound 4: middle estimate off by 4.5-fold (0.66 log units), on the high side, outside the stated range (below it).
By their numbers in this assay, from the lowest: compounds 4, 1, 3 and 2 (each within the scatter of the next, the first and the last beyond it).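

In this assay, going from 4-chlorophenyl to 4-methoxyphenyl with the 4-(tert-butyl)phenyl group in place gives a 1.6-fold lower number from compound 3 to compound 4 (0.21 log units; within the scatter), so on this partner the change cannot be told apart from scatter. The earlier single example suggested a clear rise, but the effect of this change evidently depends on the group at the other point of the molecule, since its two examples disagree: the same change on two cores in this assay, a 3.1-fold higher number (0.49 log units; beyond the scatter) from compound 1 to compound 2 and a 1.6-fold lower number (0.21 log units; within the scatter) from compound 3 to compound 4, 5.1-fold (0.71 log units) apart, beyond the scatter of two such steps The reverse view tells the same story, because replacing 6-chloropyridin-3-yl with 4-(tert-butyl)phenyl gives a 3.2-fold lower number from compound 2 to compound 4 (0.50 log units; beyond the scatter) when methoxy is present, a clearer step than the one seen with chloro present: the same change on two cores in this assay, a 1.6-fold higher number (0.20 log units; within the scatter) from compound 1 to compound 3 and a 3.2-fold lower number (0.50 log units; beyond the scatter) from compound 2 to compound 4, 5.1-fold (0.71 log units) apart, beyond the scatter of two such steps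

The compounds shown carry only chloro or methoxy at this place on the ring, so it remains open whether an amine or a longer ether such as ethoxy would behave like either of them on the two partners. With just one pair of examples for each change, these four compounds show that the two points do not act independently in this assay, but not what lies behind that.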